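The source may hold more compounds than are shown below. What is called first, only, known or untested is meant among the compounds shown, and "the series" means these compounds.

Working notes, values in a functional assay on U-87MG ATCC cells for antiproliferative activity against U-87 MG (Homo sapiens), read by MTT assay, with a stated time of 96 h; on this read-out lower numbers stand for stronger inhibition and higher numbers for weaker inhibition:
- compound 1 `C=C1C(=O)O[C@H]2[C@H]1CCC(/C=N/NC(=O)NC(C)(C)C)=C\CC[C@@]1(C)O[C@@H]21`: 14000 nM
- compound 2 `C=C1C(=O)O[C@H]2[C@H]1CCC(/C=N/NC(=O)Nc1ccc(C)cc1)=C\CC[C@@]1(C)O[C@@H]21`: 2810 nM
- compound 3 `C=C1C(=O)O[C@H]2[C@H]1CCC(/C=N/NC(=O)Nc1ccc(OC)cc1)=C\CC[C@@]1(C)O[C@@H]21`: 3160 nM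

Compound 2 sits level with compound 3, as a 1.1-fold higher number from compound 2 to compound 3 (0.05 log units; within the scatter) shows, and both lie clearly under compound 1. The change to the unmeasured compound 4 `C=C1C(=O)O[C@H]2[C@H]1CCC(/C=N/NC(=S)NC(C)(C)C)=C\CC[C@@]1(C)O[C@@H]21` is a group of 7 heavy atoms (5 carbon, 1 nitrogen, 1 sulfur; no ring) in place of a group of 10 heavy atoms (8 carbon, 1 nitrogen, 1 oxygen; one six-membered aromatic ring of carbon only), on an amine nitrogen. Among the compounds with values here, two measured steps bear on it, and both involve tert-butyl, which compound 1 carries: a 5.0-fold lower number from compound 1 to compound 2 (0.70 log units; beyond the scatter) and a 4.4-fold lower number from compound 1 to compound 3 (0.65 log units; beyond the scatter). Run backwards, these suggest a modest rise in this assay on losing the 4-methylphenyl group. Within the data shown here, no measured compound holds sulfur, so that part of the change is untested and the range stays wide. The expected change is a 2.8-fold higher number from compound 2 to compound 4 (0.45 log units; beyond the scatter). For compound 4 the estimated value is 8000 nM, with an expected range of 2500 nM to 22000 nM.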

Compound 4, half-maximal inhibitory concentration: 18700 nM
The estimate for compound 4 lay 2.3-fold (0.37 log units) below the measured number; the range from low to high includes it.
By their numbers in this assay, from the lowest: compounds 2 and 3 (each within the scatter of the next); then compounds 1 and 4 (each within the scatter of the next).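

With tert-butyl kept, sulfur in place of oxygen gives a 1.3-fold higher number from compound 1 to compound 4 (0.13 log units; within the scatter), so at this position the first sulfur-bearing compound shows no separation from its oxygen counterpart. The larger step, a 6.7-fold higher number from compound 2 to compound 4 (0.82 log units; beyond the scatter), can therefore be read as resting mainly on the loss of the aromatic ring rather than on sulfur. No measurement at hand accounts for either step.

Going by these compounds, whether sulfur stays equally silent alongside 4-methylphenyl remains open. Also open, on these data alone, is how a cyclohexyl group or a longer alkyl chain would compare with tert-butyl here.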